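Swapping the halogen at the far end of a bis-furan amidine

The source may hold more compounds than are shown below. What is called first, only, known or untested is meant among the compounds shown, and "the series" means these compounds.

Measured compounds:
- compound 1, `N=C(N)c1ccc(-c2ccc(-c3cncc4ccccc34)s2)s1`: 750 nM
- compound 2, `N=C(N)c1ccc(-c2ccc(-c3ccc(F)cc3)o2)o1`: 1600 nM

Of the compounds shown here, two have been tested in a functional assay on COLO 205 cells (Homo sapiens) for inhibition, read by sulforhodamine B assay, with a stated time of 48 h; on this read-out higher numbers stand for weaker inhibition of growth and lower numbers for stronger inhibition of growth. Compound 1 gives 750 nM, and compound 2 gives 1600 nM. Of the two numbers, compound 2 has the higher one, and the gap between compound 2 and compound 1 lies beyond the usual scatter of this assay, so compound 2 is the weaker inhibitor of growth of the pair.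

The next compound keeps the core of compound 2 and changes a single group on the outer ring. Compound 3, `N=C(N)c1ccc(-c2ccc(-c3ccc(Cl)cc3)o2)o1`, differs from compound 2 by chloro in place of fluoro on an aromatic carbon. Going by the values given here, no step between two measured compounds of this kind is available, so nothing in the data itself tells how such a change moves the number. With only the halogen exchanged and the rest of the molecule unchanged, the step from compound 2 to compound 3 is expected to be small, close to the scatter, with no firm direction; the expected step is a 1.3-fold lower number from compound 2 to compound 3 (0.12 log units; within the scatter). Compound 3 is therefore estimated to give about 1200 nM in this assay, with a range from 500 nM to 3000 nM.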

Compound 3, concentration for 50% growth inhibition: 1830 nM
Estimate against measurement, compound 3: 1.5-fold (0.18 log units) below; the range from low to high includes it.
By their numbers in this assay, from the lowest: compound 1; then compounds 2 and 3 (each within the scatter of the next).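

In this assay chloro in place of fluoro on an aromatic carbon para to a large group gives a 1.1-fold higher number from compound 2 to compound 3 (0.06 log units; within the scatter) and so the two halogens cannot be told apart on this read-out. Going by these compounds alone, this is the first step that changes one place only, and it shows that on the core of compound 2 this position accepts either fluoro or chloro with no change that the assay can resolve. It is still a single pair of compounds, and nothing measured here accounts for the result or links it to any property of either halogen.

The compounds shown leave open whether this position is equally undemanding for groups of a different kind, such as an amine, a carboxylic acid or a longer chain like butyl, or whether one of these would move the number beyond the scatter. As far as these compounds go, it also remains open whether a plain hydrogen at this position would give a similar number, and whether exchanging one halogen for the other would go the same way on a different core.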